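This account rests on a few compounds, and the source may have more. Where it says the series, first, only, none or still open, it means among the compounds named here.

Measured so far:
- compound 1 `Cc1[nH]c(=O)n(C)c1-c1ccc(OC(C)C)cc1` at 20400 nM
- compound 2 `Cc1[nH]c(=O)n(C)c1-c1ccc(OCc2ccccc2)cc1` at 6700 nM
- compound 3 `Cc1[nH]c(=O)n(C2CCCCC2)c1-c1ccc(OC(C)C)cc1` at 13000 nM

These values come from a functional assay on brain (Rattus norvegicus, strain Wistar) for inhibition (on this read-out lower numbers stand for stronger inhibition and higher numbers for weaker inhibition), and are the only ones available for the series. Compound 3 at 13000 nM lies within the scatter of both compound 1 and compound 2, although those two differ from each other beyond it.

Next is compound 4 `CCCCCCCc1ccc(-c2c(C)[nH]c(=O)n2C2CCCCC2)cc1` with heptyl in place of isopropoxy on an aromatic carbon and the cyclohexyl group of compound 3 retained. The nearest guide is a 3.0-fold lower number from compound 1 to compound 2 (0.48 log units; beyond the scatter) for benzyl in place of isopropyl on an oxygen on an aromatic ring, a modest step beyond the scatter. The other measured step is a 1.6-fold lower number from compound 1 to compound 3 (0.20 log units; within the scatter) for cyclohexyl in place of methyl on an aromatic nitrogen, which stays within the scatter and leaves the changing group untouched. Going by the values given here, no measured step removes the oxygen, so the guide is only partial and the range is wide.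

The step expected in this assay is a 2.9-fold lower number from compound 3 to compound 4 (0.46 log units; beyond the scatter) and would be modest, towards a lower number. The estimated value for compound 4 is 4500 nM with an expected range from 1200 nM to 15000 nM in this read-out.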

Compound 4, half-maximal inhibitory concentration: 8700 nM
The estimate for compound 4 lay 1.9-fold (0.29 log units) below the measured number; measured number inside the range.
By their numbers in this assay, from the lowest: compounds 2, 4, 3 and 1 (each within the scatter of the next, the first and the last beyond it).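

In this assay, heptyl in place of isopropoxy on an aromatic carbon gives a 1.5-fold lower number from compound 3 to compound 4 (0.17 log units; within the scatter), so at this place the number stays within the scatter when the group changes from one with an oxygen to an all-carbon chain. Compounds 1, 2 and 3 all keep an oxygen on the aromatic carbon, whereas compound 4 shows that a group with no hydrogen-bond acceptor can stand there without a change beyond the scatter. Nothing measured here bears on why the two groups read alike.

Open, as far as these compounds go, is whether a shorter chain, a carboxylic acid or an amine at the end of the chain would keep the number at this level. Also open, from the compounds shown here alone, is whether heptyl would read the same with methyl instead of cyclohexyl on the aromatic nitrogen.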